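Cyclopropyl for methoxyphenyl on the ring amide nitrogen

This account rests on a few compounds, and the source may have more. Where it says the series, first, only, none or still open, it means among the compounds named here.

Going by the values given here, compound 1 `COc1cccc(N2C(=O)COc3ccc(-c4cnc(Cl)c(NS(=O)(=O)c5ccc(F)cc5)c4)cc32)c1` and compound 2 `O=C1COc2ccc(-c3cnc4ccccc4c3)cc2N1` are the two measured members. In a functional assay on HeLa cells (Homo sapiens) for antiproliferative activity, read by MTT assay, with a stated time of 72 h (a lower number here means a stronger inhibitor, a higher number a weaker inhibitor), compound 1 returns only a limit, > 40000 nM, not a number. Compound 2 in this assay also returns only a limit, > 40000 nM. Among the compounds with values here, the evidence on the measured side is therefore confined to the limit of > 40000 nM in this assay, at which 2 of the 2 values shown sit, so compound 1 stands at the limit with no value of its own, and no step between measured compounds can be drawn.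

Compound 3 `O=C1COc2ccc(-c3cnc(Cl)c(NS(=O)(=O)c4ccc(F)cc4)c3)cc2N1C1CC1` differs from compound 1 in one place: cyclopropyl in place of 3-methoxyphenyl on an amide-type nitrogen in a ring. With both measured compounds at the limit, the expected step of an at least 1.1-fold lower number from compound 1 to compound 3 (0.05 log units; that floor lies within the scatter) is none beyond the scatter. It is expected that compound 3 may again return only a limit in this assay. The estimate for compound 3 is 35000 nM, with a range from 8000 nM to 120000 nM.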

Compound 3, half-maximal inhibitory concentration: 7180 nM
For compound 3 the middle estimate is 4.9-fold (0.69 log units) above the measured one; measured number below the stated range.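

Going by these compounds alone, compound 3 is the first compound with a number of its own in this assay, so the group on the amide-type nitrogen in the ring is a place where the read-out can leave the limit. Cyclopropyl in place of 3-methoxyphenyl at this nitrogen gives an at least 5.5-fold lower number from compound 1 to compound 3 (0.74 log units; beyond the scatter). That step has a floor but no measured size, because compound 1 stands at a limit and has no number: the limit of > 40000 nM in this assay, at which 2 of the 3 values shown sit.

This single pair does not separate the loss of the aromatic ring from the loss of the methoxy oxygen or from the change in group size. On these data alone, how a plain phenyl, a methyl or a longer alkyl chain on the same nitrogen would read in this assay remains open.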